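A few compounds are considered here, and "the series" means these few. Any claim that something is new, unique, unknown or untested is made for them only; others in the source may bear on it.

Measured in a functional assay on K562 cells (Homo sapiens) for cytotoxicity, read by trypan blue exclusion, with a stated time of 96 h; a lower number here means a stronger inhibitor, a higher number a weaker inhibitor:
compound 1 `COc1ccc(CS(=O)(=O)/C=C/c2c(OC)cc(OC)cc2OC)c(N)c1`: 25 nM
compound 2 `COc1cc(OC)c(/C=C/S(=O)(=O)Cc2cc(N)ccc2OC)c(OC)c1`: 7500 nM
compound 3 `COc1cc(OC)c(/C=C/S(=O)(=O)Cc2ccc(Br)c(N)c2)c(OC)c1`: 750 nM

Compound 3, at 750 nM, holds the middle of these three numbers. Two steps place it: a 10-fold lower number from compound 2 to compound 3 (1.00 log units; beyond the scatter), and a 30-fold higher number from compound 1 to compound 3 (1.48 log units; beyond the scatter).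

Compound 4 `COc1cc(OC)c(/C=C/S(=O)(=O)Cc2ccc(Cl)c(N)c2)c(OC)c1` has not been measured. It keeps all of compound 3 except one group: chloro in place of bromo on an aromatic carbon. In words, this is chloro in place of bromo on an aromatic carbon, turning 3-amino-4-bromophenyl into 3-amino-4-chlorophenyl.

Going by the values given here, no measured step makes this exchange. The closest evidence comes from steps that replace the whole substituted phenyl group: a 300-fold higher number from compound 1 to compound 2 (2.48 log units; beyond the scatter), which is large, alongside the two steps above. They show that the number can move a long way when that group is rebuilt, but they give no size for swapping bromo alone, a far smaller change. The data offer no direction for it either, so the range is kept wide. In this assay, no step beyond the scatter is expected, and the estimate amounts to a 1.1-fold lower number from compound 3 to compound 4 (0.03 log units; within the scatter). For compound 4 the estimated value is 700 nM, with an expected range from 200 nM to 2500 nM.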

Compound 4, half-maximal inhibitory concentration: 10 nM
Compound 4: middle estimate off by 70-fold (1.85 log units), on the high side; the measured number lies below the stated range.
By their numbers in this assay, from the lowest: compound 4; then compound 1; then compound 3; then compound 2.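

In this assay the exchange of bromo for chloro, on an aromatic carbon ortho to an amino group, gives a 75-fold lower number from compound 3 to compound 4 (1.88 log units; beyond the scatter) and so shows that this position is far from indifferent to which halogen it carries, even though one heavy atom simply replaces another and the hydrogen-bond donor and acceptor counts stay at zero. The size of this single-atom step rivals those seen when the whole substituted phenyl group is rebuilt: the 3-amino-4-chlorophenyl group gives a 750-fold lower number from compound 2 to compound 4 (2.88 log units; beyond the scatter) and also a 2.5-fold lower number from compound 1 to compound 4 (0.40 log units; beyond the scatter) in a smaller but still clear step, so compound 4 now has the lowest number of the four and the 2-amino-4-methoxyphenyl group no longer leads the set. No measured evidence is available to explain why the two halogens differ so sharply.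

Going by these compounds, the finding rests on one pair of compounds, so it remains open whether fluoro, iodo or a methyl group on this carbon would behave more like chloro or like bromo. On these data alone, it also remains open whether the step would persist if a hydroxyl group took the place of the amino group.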